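The source may report more compounds than this note shows. Statements on the series, on what has been measured and on what is new or still open speak of the compounds shown alone.

Measured in a functional assay on MDA-MB-231 cells (Homo sapiens) for antiproliferative activity, with a stated time of 4 days; a higher number here means a weaker inhibitor, a lower number a stronger inhibitor:
- compound 1 `COc1ccc(-c2[nH]c3ccccc3c2C=O)cc1`: 470 nM
- compound 2 `COc1ccc(-c2[nH]c3ccc(OC)cc3c2C=C(C#N)C#N)cc1`: 590 nM

At 590 nM, compound 2 stands level with compound 1, since their two values lie within the usual scatter. Compound 3 `COc1ccc(-c2[nH]c3ccc(C(C)C)cc3c2C=C(C#N)C#N)cc1` has isopropyl in place of methoxy on an aromatic carbon of compound 2 (isopropyl in place of methoxy on an aromatic carbon). Among the measured compounds shown here, no measured pair shows what this exchange does, so no step beyond the scatter is expected in this assay, and either direction remains possible. The expected change, a 1.2-fold lower number from compound 2 to compound 3 (0.07 log units; within the scatter), is correspondingly small. For compound 3 the estimate is 500 nM, with an expected range of 100 nM to 2000 nM.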

Compound 3, half-maximal inhibitory concentration: 210 nM
The estimate for compound 3 lay 2.4-fold (0.38 log units) above the measured number; low and high end bracket the measured number.
By their numbers in this assay, from the lowest: compound 3; then compounds 1 and 2 (each within the scatter of the next).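

In this assay, this position on the shared core proves sensitive to its substituent: isopropyl in place of methoxy gives a 2.8-fold lower number from compound 2 to compound 3 (0.45 log units; beyond the scatter) and is the only single-place step shown. The lower number also shows that the position does not need the hydrogen-bond acceptor counted for methoxy, since the all-carbon isopropyl does better here. No supporting measurement is available to explain this step. From the compounds shown here alone, what an amine, a carboxylic acid or a longer chain would do at this position remains open. Going by these compounds, whether the exchange would give a similar step on another core also remains open.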